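Pyridin-3-yl for 1,2-oxazol-3-yl on an amide carbonyl

The source may report more compounds than this note shows. Statements on the series, on what has been measured and on what is new or still open speak of the compounds shown alone.

Compound 1 `O=C(Nc1ccc(Cl)c(-c2nnc3c(Cl)cccn23)c1)c1c(F)cccc1Cl`, compound 2 `O=C(Nc1ccc(Cl)c(-c2nnc3c(Cl)cccn23)c1)c1ccon1` and compound 3 `O=C(Nc1ccc(Cl)c(-c2nnc3c(Cl)cccn23)c1)c1ccc(C(F)(F)F)cc1Cl` share one core and differ only in the group attached to the carbonyl carbon of the amide. In a functional assay on A549 cells (Homo sapiens) for antiproliferative activity, read by MTT assay, with a stated time of 72 h (on this read-out higher numbers stand for weaker inhibition and lower numbers for stronger inhibition), compound 1 gives 72300 nM, and compound 2 gives 42700 nM. For compound 3 this assay reports only a limit, > 100000 nM, and no number. Of the two numbers shown, compound 2 stands at the low end, but the step of a 1.7-fold lower number from compound 1 to compound 2 (0.23 log units; within the scatter) is within the scatter, so the two compounds are not told apart. Compound 4 `O=C(Nc1ccc(Cl)c(-c2nnc3c(Cl)cccn23)c1)c1cccnc1` has not yet been measured; it differs from compound 2 as follows: pyridin-3-yl in place of 1,2-oxazol-3-yl on a carbonyl carbon. Among the compounds with values here, the only measured step that bears on an exchange of the group on the carbonyl carbon is a 1.7-fold lower number from compound 1 to compound 2 (0.23 log units; within the scatter), and it stayed within the scatter, while the limit of > 100000 nM in this assay, at which 1 of the 3 values shown sits, shows that one such exchange reaches the limit. Compound 4 is therefore expected to move little, with a 1.1-fold higher number from compound 2 to compound 4 (0.02 log units; within the scatter) not beyond the scatter. Compound 4 is estimated at 45000 nM, within 15000 nM to 100000 nM.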

Compound 4, half-maximal inhibitory concentration: > 100000 nM
Compound 4: a limit, no number (the forecaster's own chance of this, stated with the estimate: 25%); at least 2.2-fold (0.34 log units) between middle value and limit.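

Within the data shown here, with an at least 2.3-fold higher number from compound 2 to compound 4 (0.36 log units; beyond the scatter) an exchange of the group on the carbonyl carbon passes beyond the scatter for the first time, although this step rests on a limit and gives only a floor. The other reading is an at least 1.3-fold higher number from compound 1 to compound 4 (0.14 log units; that floor lies within the scatter) and so does not separate those two compounds. In this assay compound 4 gives > 100000 nM, which is a limit and not a number, and it now stands with compound 3 at that limit: the limit of > 100000 nM in this assay, at which 2 of the 4 values shown sit.

Going by these compounds, how far compound 4 lies from compound 2 remains unknown, since only the floor of that step can be read. Also open, on these data alone, is whether an amine such as piperidin-4-yl, or a phenyl ring carrying a carboxylic acid, would give a lower number than compound 2 when placed on the carbonyl carbon.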